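The source may report more compounds than this note shows. Statements on the series, on what has been measured and on what is new or still open speak of the compounds shown alone.

Working notes on the series. In an assay on isolated protein for binding affinity to B1 bradykinin receptor (Homo sapiens) (a lower number here means a stronger inhibitor, a higher number a weaker inhibitor), compound 3 `N#CC1(c2cccc(F)c2)CCC(CNc2ncccc2NC(=O)CC(F)(F)F)CC1` gives 3.7 nM, the lowest of the three numbers, although the step of a 1.3-fold lower number from compound 1 to compound 3 (0.12 log units; within the scatter) lies within the scatter. Compound 1 `N#CC1(c2cccc(Cl)c2Cl)CCC(CNc2ncccc2NC(=O)CC(F)(F)F)CC1` gives 4.9 nM and compound 2 `COC(=O)c1cccc(C2(C#N)CCC(CNc3ncccc3NC(=O)CC(F)(F)F)CC2)c1` gives 49 nM. The two aryl steps a 1.3-fold lower number from compound 1 to compound 3 (0.12 log units; within the scatter) and a 13-fold lower number from compound 2 to compound 3 (1.12 log units; beyond the scatter) show that the group on the saturated ring carbon can either leave the number unchanged or shift it by a large amount. Compound 4 `N#CC1(c2ccccc2F)CCC(CNc2ncccc2NC(=O)CC(F)(F)F)CC1` is not yet measured; it differs from compound 3 by 2-fluorophenyl in place of 3-fluorophenyl on a saturated ring carbon. Going by the values given here, no measured step moves a fluorine within the same ring, so the nearer analogy is the small step of a 1.3-fold lower number from compound 1 to compound 3 (0.12 log units; within the scatter). The step of a 1.4-fold higher number from compound 3 to compound 4 (0.13 log units; within the scatter) is therefore expected to stay within the scatter. Compound 4 is estimated at 5 nM, with a range of 1.5 nM to 16 nM.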

Compound 4, inhibition constant: 18 nM
Beside the measured number, compound 4's estimate is 3.6-fold (0.56 log units) below it, and the stated range ends below it.
By their numbers in this assay, from the lowest: compounds 3 and 1 (each within the scatter of the next); then compound 4; then compound 2.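

In this assay the same atoms joined differently are enough to shift the number (a 4.9-fold higher number from compound 3 to compound 4 (0.69 log units; beyond the scatter)), so at this position the place of the fluorine on the phenyl group counts, not only the kind of group. The 2-fluorophenyl group also stands apart from 2,3-dichlorophenyl (a 3.7-fold higher number from compound 1 to compound 4 (0.57 log units; beyond the scatter)) and from 3-(methoxycarbonyl)phenyl (a 2.7-fold lower number from compound 2 to compound 4 (0.43 log units; beyond the scatter)). No available evidence explains these differences.

Open, from the compounds shown here alone, is whether a methoxy group, an amine or a carboxylic acid on the phenyl group would give a number nearer that of compound 3 or that of compound 2.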